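The source may hold more compounds than are shown below. What is called first, only, known or untested is meant among the compounds shown, and "the series" means these compounds.

Measured in a functional assay on cells (Neutrophil, Homo sapiens) for inhibition, with a stated time of 10 min; on this read-out lower numbers stand for stronger inhibition and higher numbers for weaker inhibition:
- compound 1 `CCOC(=O)c1cnn2c1N(C(=O)Nc1ccccc1)C(c1ccccc1)C2`: > 1000 nM, a limit of the assay and not a number
- compound 2 `CCOC(=O)c1cnn2c1N(C(=O)Nc1cccc(F)c1)C(c1ccccc1)C2`: 111 nM
- compound 3 `CCOC(=O)c1cnn2c1N(C(=O)Nc1cccc3ccccc13)C(c1ccccc1)C2`: 206 nM

Compound 1 stands at the limit of > 1000 nM in this assay, at which 1 of the 3 values shown sits. Compound 4 `O=C(c1cnn2c1N(C(=O)Nc1ccccc1)C(c1ccccc1)C2)N1CCCCC1` keeps the core of compound 1 and differs in one group: piperidin-1-yl in place of ethoxy on a carbonyl carbon. In words, this is piperidin-1-yl in place of ethoxy on a carbonyl carbon. The measured steps of an at least 9.0-fold lower number from compound 1 to compound 2 (0.95 log units; beyond the scatter) and an at least 4.8-fold lower number from compound 1 to compound 3 (0.68 log units; beyond the scatter) were made at another place, so neither gives a size for this change. Among the measured compounds shown here, no measured step touches this carbonyl, and no step beyond the scatter is therefore expected in this assay. The expected step is a step that the limit leaves unreadable from compound 1 to compound 4. For compound 4 the estimated value is 1500 nM, with an expected range from 400 nM to 6000 nM.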

Compound 4, half-maximal inhibitory concentration: > 1000 nM
Compound 4: no number, only a limit (the forecaster's own chance of this, stated with the estimate: 65%); the middle value is on the limit's open side.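

Compound 1 and compound 4 each give only a limit and not a number, so the step between them cannot be read: the limit of > 1000 nM in this assay, at which 2 of the 4 values shown sit.

From the compounds shown here alone, whether piperidin-1-yl in place of ethoxy changes inhibition at all stays open.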